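Cytotoxicity notes: pyridyl for fluorophenyl on the shared core

The compounds below may be only part of what the source reports. "The series", "measured", "known", "first", "only" and "open" are said of these compounds alone.

Going by the values given here, compound 1 `N#C/C=C/c1cc(F)c(Oc2nc(Nc3ccc(C#N)c(F)c3)nc3sccc23)c(F)c1` gives the higher of the two numbers so far in a toxicity assay on MT4 cells (Homo sapiens) for cytotoxicity, read by MTT assay, with a stated time of 5 days (on this read-out higher numbers stand for lower toxicity in this test and lower numbers for higher toxicity in this test), at 117000 nM. Compound 2 `N#C/C=C/c1cc(F)c(Oc2nc(Nc3ccc(C#N)nc3)nc3ccsc23)c(F)c1` differs from compound 1 in several places. In this assay compound 2 gives 47500 nM, a gap from compound 1 that the two values show to lie beyond the scatter. Compound 3 `N#C/C=C/c1cc(F)c(Oc2nc(Nc3ccc(C#N)nc3)nc3sccc23)c(F)c1` carries the amine substituent of compound 2 on the core of compound 1: the change is 6-cyanopyridin-3-yl in place of 4-cyano-3-fluorophenyl on a nitrogen on an aromatic ring. Among the compounds with values here, no single-change step has been measured, so the size of this step is an estimate; the step from compound 1 to compound 3 in this assay is expected to be small and downward, a 1.6-fold lower number from compound 1 to compound 3 (0.19 log units; within the scatter), with compound 2 at 47500 nM the only anchor on the pyridyl side. Compound 3 is therefore estimated at 75000 nM, in a range from 30000 nM to 180000 nM.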

Compound 3, half-maximal cytotoxic concentration: 12800 nM
Compound 3: the middle estimate sits 5.9-fold (0.77 log units) above what was measured, outside the stated range (below it).
By their numbers in this assay, from the lowest: compound 3; then compound 2; then compound 1.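

In this assay, going by these compounds alone, the change from 4-cyano-3-fluorophenyl to 6-cyanopyridin-3-yl on a nitrogen on an aromatic ring gives a 9.1-fold lower number from compound 1 to compound 3 (0.96 log units; beyond the scatter) and is the first single-place step. This position therefore bears on the read-out, with the pyridyl compound showing the higher toxicity in this test. Nothing shown gives a measured reason for the size of this step.

The change removes the fluorine and brings in the ring nitrogen together, so the two cannot be told apart here, and a 4-cyanophenyl group on the same nitrogen, which carries neither, would be the compound to separate them. Also open is whether a step of this size holds on the core of compound 2, where the 4-cyano-3-fluorophenyl partner is not among the compounds shown.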